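The source may report more compounds than this note shows. Statements on the series, on what has been measured and on what is new or still open speak of the compounds shown alone.

Among the measured compounds shown here, in a functional assay on QGY cells (Homo sapiens) for cytotoxicity, read by MTT assay, with a stated time of 48 h (a higher number here means a weaker inhibitor, a lower number a stronger inhibitor), compound 1 `COc1cc([C@@H]2C[C@]2(CO)C(=O)NCc2ccc(C)cc2)cc(OC)c1OC` gives 25100 nM and the only other measured compound, compound 2 `CCOC(=O)[C@]1(C(=O)NCc2ccc(C)cc2)C[C@H]1c1cc(OC)c(OC)c(OC)c1` gives 32100 nM in the same test. That gap, a 1.3-fold higher number from compound 1 to compound 2 (0.11 log units; within the scatter) for ethoxycarbonyl in place of hydroxymethyl on a saturated ring carbon, lies within the scatter. Compound 3 `COc1cc([C@H]2C[C@@]2(CO)C(=O)NCc2ccc(C)cc2)cc(OC)c1OC` is a change of another kind: the two compounds have the same atoms and bonds and differ only in configuration as drawn: 2 of 2 stereo elements differ (all stereocentres are inverted: mirror images); a stereocentre at a saturated ring carbon is drawn S in compound 1 and R in compound 3; a stereocentre at a saturated ring carbon is drawn S in compound 1 and R in compound 3 and no atom or bond changes. For the measured compounds named here, no measured step tests such an inversion, so the guide is weak. The expected step is a 1.1-fold higher number from compound 1 to compound 3 (0.03 log units; within the scatter) and so none beyond the scatter. For compound 3 the estimated value is 27000 nM with an expected range from 11000 nM to 65000 nM in this test.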

Compound 3, half-maximal inhibitory concentration: > 100000 nM
Compound 3 ended at the assay's limit; the forecaster's own chance of this, stated with the estimate: 15%; middle value at least 3.7-fold (0.56 log units) from the limit.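

In this assay, inverting both stereocentres gives an at least 3.9-fold higher number from compound 1 to compound 3 (0.60 log units; beyond the scatter) while the earlier change of hydroxymethyl to ethoxycarbonyl stayed within the scatter. Compound 3 gives > 100000 nM as a limit of the assay and not a number. This step can be laid to configuration alone: the fact that compounds 1 and 3 differ only in the configuration as drawn.

From the compounds shown here alone, both stereocentres invert together in compound 3, so it remains open whether one alone would carry the step, and whether the mirror image of compound 2 would behave likewise. Also open, going by these compounds, is how a carboxylic acid or an amine in place of the hydroxymethyl would fare in either configuration.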